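Trifluoromethyl for Chloro on a Sulfamoyl-Bearing Aniline

A few compounds are considered here, and "the series" means these few. Any claim that something is new, unique, unknown or untested is made for them only; others in the source may bear on it.

Compound 1 `CC1(C)C[C@H](O)C[C@](C)(CNc2cccc(Cl)c2)C1` was measured in an in vitro ADME assay on microsomes from liver (Mus musculus) for pharmacokinetics, tested at 1 uM (on this read-out lower numbers stand for slow clearance and higher numbers for fast clearance), where compound 1 gives 86.1 mL/min/kg. Compound 2 `CC1(C)C[C@H](O)C[C@](C)(CNc2cccc(C(F)(F)F)c2)C1` carries trifluoromethyl in place of chloro on an aromatic carbon, and in this assay compound 2 gives 83.8 mL/min/kg; the step is a 1.0-fold lower number from compound 1 to compound 2 (0.01 log units; within the scatter). Compound 3 `CC1(C)C[C@H](O)C[C@](C)(CNc2cc(Cl)cc(S(N)(=O)=O)c2)C1` differs from compound 1 by sulfamoyl in place of hydrogen on an aromatic carbon, and in this assay compound 3 gives 51.8 mL/min/kg, a step of a 1.7-fold lower number from compound 1 to compound 3 (0.22 log units; within the scatter).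

Compound 4 `CC1(C)C[C@H](O)C[C@](C)(CNc2cc(C(F)(F)F)cc(S(N)(=O)=O)c2)C1` has no value yet in this assay. Its difference from compound 3 is trifluoromethyl in place of chloro on an aromatic carbon, the same kind of change as from compound 1 to compound 2, though here the place is also meta to a sulfamoyl group, which the earlier place was not. Because the earlier step was a 1.0-fold lower number from compound 1 to compound 2 (0.01 log units; within the scatter), a step of similar size is expected, namely a 1.0-fold lower number from compound 3 to compound 4 (0.02 log units; within the scatter). Compound 4 is therefore estimated at 50 mL/min/kg in this assay, with a likely span from 30 mL/min/kg to 85 mL/min/kg.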

Compound 4, clearance: 39.6 mL/min/kg
Beside the measured number, compound 4's estimate is 1.3-fold (0.10 log units) above it, and the stated range covers the measured number.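

In this assay, trifluoromethyl in place of chloro gives a 1.3-fold lower number from compound 3 to compound 4 (0.12 log units; within the scatter) where a sulfamoyl group is present, and this matches the same change without one: the same change on two cores in this assay, a 1.0-fold lower number (0.01 log units; within the scatter) from compound 1 to compound 2 and a 1.3-fold lower number (0.12 log units; within the scatter) from compound 3 to compound 4, 1.3-fold (0.10 log units) apart, within the scatter of two such steps. Sulfamoyl in place of hydrogen gives a 2.1-fold lower number from compound 2 to compound 4 (0.33 log units; beyond the scatter), which lies beyond the scatter, yet it too stays in line with its earlier counterpart, which lay within the scatter: the same change on two cores in this assay, a 1.7-fold lower number (0.22 log units; within the scatter) from compound 1 to compound 3 and a 2.1-fold lower number (0.33 log units; beyond the scatter) from compound 2 to compound 4, 1.3-fold (0.10 log units) apart, within the scatter of two such steps. Each change therefore carried from one core to the other here without a difference that can be told from the scatter, but this rests on a single pair of steps for each change and does not show that either step would hold on any other core or explain why the steps agree.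

The compounds shown leave open whether a nitrile in place of trifluoromethyl or chloro would follow the same step. They also leave open whether a carboxylic acid or an amine in place of sulfamoyl would do so.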